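Working notes: from compound 2 to compound 3

A few compounds are considered here, and "the series" means these few. Any claim that something is new, unique, unknown or untested is made for them only; others in the source may bear on it.

Two compounds carry numbers in a functional assay on Venous blood for antagonist activity at C-X-C chemokine receptor type 3 (Homo sapiens), read by flow cytometry, with a stated time of 30 min, in the presence of a further agent that is not named here; a lower number here means a stronger inhibitor, a higher number a weaker inhibitor. Compound 1, `Cc1nc(C)n(CC(=O)N2CCN(c3sc(C(F)(F)F)nc3-c3nc4ccc(C5CCN(C)CC5)cc4[nH]3)C[C@H]2C)n1`, gives 84.7 nM in this assay. Compound 2, `C[C@@H]1CN(c2sc(C(F)(F)F)nc2-c2nc3ccccc3[nH]2)CCN1C(=O)Cn1cnc2c1CCN(C)C2`, gives 135 nM in this assay, the higher of the two numbers, but its gap to compound 1 lies within the scatter, so the two are not separated by the data.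

Compound 3, `C[C@@H]1CN(c2sc(C(F)(F)F)nc2-c2nc3ccccc3[nH]2)CCN1C(=O)Cn1ccc(C(=O)O)n1`, has not yet been measured. It differs from compound 2 in one place: a group of 8 heavy atoms (4 carbon, 2 nitrogen, 2 oxygen; one five-membered aromatic ring with 2 hetero atoms) in place of a group of 10 heavy atoms (7 carbon, 3 nitrogen; one five-membered aromatic ring with 2 hetero atoms, one six-membered non-aromatic ring with 1 hetero atom), on a saturated chain carbon bound to a carbonyl carbon. The exchange sits on a saturated chain carbon bound to a carbonyl carbon, and the rest of the molecule is unchanged.

For the measured compounds named here, no step between measured compounds is available, so the size of this change cannot be calibrated from the series; the two measured compounds differ elsewhere and sit within the scatter of each other. The expectation is a modest move toward a higher number, around the edge of the scatter, as a 1.9-fold higher number from compound 2 to compound 3 (0.28 log units; within the scatter). Compound 3 is accordingly estimated at 260 nM in this assay, with a range from 80 nM to 900 nM.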

Compound 3, half-maximal inhibitory concentration: 5570 nM
For compound 3 the middle estimate is 21-fold (1.33 log units) below the measured one; the whole stated range lies below it.
By their numbers in this assay, from the lowest: compounds 1 and 2 (each within the scatter of the next); then compound 3.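

In this assay, for the compounds shown here, the place on a saturated chain carbon bound to a carbonyl carbon proves far from indifferent to what it carries: exchanging the group of 10 heavy atoms for 3-carboxy-1H-pyrazol-1-yl gives a 41-fold higher number from compound 2 to compound 3 (1.62 log units; beyond the scatter), a large step and the first single-place change that can be read. The exchange alters several things together, as the entering group brings a hydrogen-bond donor and a double bond outside aromatic rings, while the six-membered non-aromatic ring of the leaving group is lost. No measurement at hand separates these differences or accounts for the size of the step.

The compounds shown leave open whether the step follows the carboxylic acid or the loss of the six-membered non-aromatic ring: a methyl ester or a primary amide on the same five-membered ring would separate the two. On these data alone, it also remains open whether 3-carboxy-1H-pyrazol-1-yl would give a step of similar size on the core of compound 1.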